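The source may hold more compounds than are shown below. What is called first, only, known or untested is meant among the compounds shown, and "the series" means these compounds.

Within the data shown here, in an assay on HEK293 cells for inhibition of Ataxin-2 (Mus musculus), read by fluorescence and Amplex Red (a lower number here means a stronger inhibitor, a higher number a weaker inhibitor), compound 2 `O=C(O)c1ccc(COc2ccc(CNC(=O)[C@@H]3CCC(=O)N3Cc3ccccc3)cc2)cc1` gives 4500 nM, the higher of the two numbers measured so far. Compound 1 `CC1(C)OB(c2ccc(COc3ccc(CNC(=O)[C@@H]4CCC(=O)N4Cc4ccc(F)cc4)cc3)cc2)OC1(C)C` gives 120 nM, but it differs from compound 2 in more than one place, so that gap is left as it stands. Compound 3 `O=C(O)c1ccc(COc2ccc(CNC(=O)[C@@H]3CCC(=O)N3Cc3ccc(F)cc3)cc2)cc1` differs from compound 2 in one place only: fluoro in place of hydrogen on an aromatic carbon. Among the measured compounds shown here, no step between measured compounds isolates this change. Its effect is expected to be small, with the step of a 1.5-fold lower number from compound 2 to compound 3 (0.18 log units; within the scatter) likely within the usual scatter or only slightly beyond it, in either direction. Compound 3 is therefore estimated at 3000 nM, with a range from 1200 nM to 9000 nM.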

Compound 3, half-maximal inhibitory concentration: > 5000 nM
Compound 3: no number, only a limit; the forecaster's own chance of this, stated with the estimate: 5%; middle value at least 1.6-fold (0.22 log units) away from the limit.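

In this assay the reading for compound 3 is a limit and not a number: the limit of > 5000 nM in this assay, at which 1 of the 3 values shown sits. Fluoro in place of hydrogen gives an at least 1.1-fold higher number from compound 2 to compound 3 (0.04 log units; that floor lies within the scatter), so the 4-fluorobenzyl group shows no gain in the carboxylic acid series, though the true size of the step stays unknown. Among these compounds, with that group held constant, the carboxylic acid in place of the boron-bearing group gives an at least 41-fold higher number from compound 1 to compound 3 (1.61 log units; beyond the scatter), the first step that isolates this exchange. Still open, going by these compounds, is how far compound 3 truly lies from compound 2. Also open, on these data alone, is whether a free boronic acid, a methyl ester or an amine at that end would match compound 1.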